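A few compounds are considered here, and "the series" means these few. Any claim that something is new, unique, unknown or untested is made for them only; others in the source may bear on it.

Of the compounds shown here, three have been measured in a physicochemical assay for solubility, in phosphate buffer; a higher number here means a more soluble compound, a lower number a less soluble compound. Compound 1 `CCOC(=O)c1cccc(Nc2ccnc(-c3ccncc3)n2)c1` gives 46000 nM. Compound 2 `CC(=O)c1ccc(Nc2cc(C)nc(-c3ccncc3)n2)cc1` gives 6000 nM. Compound 3 `CC(=O)c1cccc(Nc2cc(C)nc(-c3ccncc3)n2)c1` gives 29000 nM.

Among these three numbers compound 3 sits close to compound 1: the two values lie within the usual scatter of each other, so nothing can be said about which of them is the more soluble. Compound 2, by contrast, gives a lower number than compound 3, and that gap lies beyond the scatter.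

Compound 4 `CC(=O)c1cc(Nc2cc(C)nc(-c3ccncc3)n2)ccc1F` has not yet been measured in this assay. It differs from compound 3 in one place: fluoro in place of hydrogen on an aromatic carbon. Among the compounds with values here, no pair of measured compounds shows this same change, so no measured step can be carried over. On the evidence of the three numbers alone, the expected step from compound 3 to compound 4 in this assay is a 1.5-fold lower number from compound 3 to compound 4 (0.16 log units; within the scatter), a small shift, if any, most likely downward but not clearly beyond the scatter. For compound 4 the estimate in this assay is 20000 nM, with a range from 8000 nM to 50000 nM.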

Compound 4, solubility: 23000 nM
Compound 4: the middle estimate sits 1.2-fold (0.06 log units) below what was measured; low and high end bracket the measured number.
By their numbers in this assay, from the lowest: compound 2; then compounds 4, 3 and 1 (each within the scatter of the next).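

In this assay, placing fluoro in place of hydrogen on an aromatic carbon, ortho to an acetyl group and para to a large group, gives a 1.3-fold lower number from compound 3 to compound 4 (0.10 log units; within the scatter), so compound 3 and compound 4 cannot be told apart in this read-out. Within the data shown here, this is the first measured step that differs in one place, and it shows that this single change, at this position and on the background of compound 3, does not produce a difference beyond the scatter. Nothing available here offers an account of this outcome, and a single pair cannot show whether it extends to other compounds.

From the compounds shown here alone, it remains open whether a larger or different group at the same position, such as chloro, methoxy, an amine or a carboxylic acid, would also stay within the scatter of compound 3 in this assay. Going by these compounds, it is equally open whether fluoro would give a similar step on another aromatic carbon of the same ring, or on the background of compound 1 or compound 2.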